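Methyl for Phenyl on the Tetrazole of Compound 3

The source may report more compounds than this note shows. Statements on the series, on what has been measured and on what is new or still open speak of the compounds shown alone.

Compound 1, `Cc1nnc(SCC(=O)N/N=c2/scc(-c3ccc([N+](=O)[O-])cc3)n2-c2ccccc2)s1`: 177 ug/mL
Compound 2, `Cn1nnnc1SCC(=O)N/N=c1/scc(-c2ccc(C#N)cc2)n1-c1ccccc1`: 213 ug/mL
Compound 3, `O=C(CSc1nnnn1-c1ccccc1)N/N=c1/scc(-c2ccc([N+](=O)[O-])cc2)n1-c1ccccc1`: 14.3 ug/mL

Of the compounds shown here, three with a shared core have been measured in an ADME assay on NIH3T3 cells (Mus musculus) for cytotoxicity, read by MTT assay, with a stated time of 24 h; a higher number here means a weaker inhibitor, a lower number a stronger inhibitor. Compound 3 gives the lowest of the three numbers. For the measured compounds named here, the only single change among them is a large one: a 12-fold lower number from compound 1 to compound 3 (1.09 log units; beyond the scatter). Compound 2 is not linked to compound 3 by a single change, but its number and that of compound 3 lie apart beyond the scatter, with compound 2 the higher.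

Compound 4, `Cn1nnnc1SCC(=O)N/N=c1/scc(-c2ccc([N+](=O)[O-])cc2)n1-c1ccccc1`, has not yet been measured in this assay. It differs from compound 3 by methyl in place of phenyl on an aromatic nitrogen. Going by the values given here, no measured pair shows exactly this change. Two observations bear on it. Compound 2 carries the same 1-methyl-1H-tetrazol-5-yl group on the sulfur and gives a high number. The step of a 12-fold lower number from compound 1 to compound 3 (1.09 log units; beyond the scatter) shows that the group on the sulfur alone can shift the number by a large amount, with the 1-phenyl-1H-tetrazol-5-yl group at the low end. Taking the phenyl away is therefore expected to move compound 4 back toward the numbers of compound 1 and compound 2, a step of a 10-fold higher number from compound 3 to compound 4 (1.02 log units; beyond the scatter). For compound 4 the expected value in this assay is 150 ug/mL, with a range from 55 ug/mL to 320 ug/mL.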

Compound 4, half-maximal inhibitory concentration: 167 ug/mL
Compound 4: middle estimate off by 1.1-fold (0.05 log units), on the low side, and the stated range covers the measured number.
By their numbers in this assay, from the lowest: compound 3; then compounds 4, 1 and 2 (each within the scatter of the next).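

In this assay, for the compounds shown here, this is the first pair to isolate the change on the aromatic nitrogen, and a 12-fold higher number from compound 3 to compound 4 (1.07 log units; beyond the scatter) ties the low number of compound 3 to the phenyl itself, not merely to the presence of a 1-substituted tetrazol-5-yl group on the sulfur. With methyl on that nitrogen, the two other single changes stay within the scatter: a 1.1-fold lower number from compound 1 to compound 4 (0.03 log units; within the scatter) for the change of the group on the sulfur, and a 1.3-fold lower number from compound 2 to compound 4 (0.11 log units; within the scatter) for nitro in place of cyano on an aromatic carbon, so among these compounds only the phenyl sets one number apart. Nothing measured here explains why the phenyl has so large an effect on this number.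

The compounds shown leave open whether a benzyl, a cyclohexyl or a longer alkyl chain on that nitrogen would give a number near that of compound 3 or near that of compound 4. They also leave open whether the phenyl would have the same effect with cyano in place of nitro, and whether a methoxy group or an amine on that phenyl would change it.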